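Alkoxy chain variation on the chalcone series: toward compound 4

A few compounds are considered here, and "the series" means these few. Any claim that something is new, unique, unknown or untested is made for them only; others in the source may bear on it.

Measured so far in a functional assay on MDA-MB-231 cells (Homo sapiens) for antiproliferative activity, read by sulforhodamine B assay; a higher number here means a weaker inhibitor of growth, a lower number a stronger inhibitor of growth:
compound 1 `CC(C)=CCOc1cccc(O)c1C(=O)/C=C/c1ccc(O)cc1`: > 30000 nM; this value is a limit of the assay, not a number.
compound 2 `O=C(/C=C/c1ccc(O)cc1)c1c(O)cccc1OCCC1CCCC1`: 3340 nM
compound 3 `CC(C)CCOc1cccc(O)c1C(=O)/C=C/c1ccc(O)cc1`: 10300 nM

Compound 3 stands highest of the two numbers; its nearest neighbour is compound 2, with a 3.1-fold higher number from compound 2 to compound 3 (0.49 log units; beyond the scatter).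

The next compound, compound 4 `CCC(CC)COc1cccc(O)c1C(=O)/C=C/c1ccc(O)cc1`, differs from compound 3 in one place: pentan-3-yl in place of isobutyl on a saturated chain carbon bound to an oxygen on an aromatic ring. The change keeps a saturated, branched chain on the carbon bound to the ring oxygen and adds one carbon.

Among the compounds with values here, three steps bear on it. Replacing 2-methylprop-1-en-1-yl by a saturated group lowered the number in both cases: an at least 2.9-fold lower number from compound 1 to compound 3 (0.46 log units; beyond the scatter) and an at least 8.9-fold lower number from compound 1 to compound 2 (0.95 log units; beyond the scatter). Within the saturated groups, the smaller one gave the higher number: a 3.1-fold higher number from compound 2 to compound 3 (0.49 log units; beyond the scatter). A chain larger than isobutyl but smaller than cyclopentylmethyl is therefore expected to give a modestly lower number in this assay; the expected step is a 1.7-fold lower number from compound 3 to compound 4 (0.23 log units; within the scatter).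

Compound 4 is estimated at 6000 nM, with a range from 2500 nM to 15000 nM.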

Compound 4, concentration for 50% growth inhibition: 3130 nM
Beside the measured number, compound 4's estimate is 1.9-fold (0.28 log units) above it, and the stated range covers the measured number.
By their numbers in this assay, from the lowest: compounds 4 and 2 (each within the scatter of the next); then compound 3. At a limit, above all of these: compound 1.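

In this assay, pentan-3-yl in place of isobutyl on a saturated chain carbon bound to an oxygen on an aromatic ring gives a clear gain (a 3.3-fold lower number from compound 3 to compound 4 (0.52 log units; beyond the scatter)), so this position responds to a small change in an open, branched chain. A ring in the group is not needed to reach the level of cyclopentylmethyl, as compounds 2 and 4 cannot be told apart (a 1.1-fold lower number from compound 2 to compound 4 (0.03 log units; within the scatter)). Compound 1 remains a limit, so the step to the new compound gives only a bound (an at least 9.5-fold lower number from compound 1 to compound 4 (0.98 log units; beyond the scatter)), and its size is not fixed: the limit of > 30000 nM in this assay, at which 1 of the 4 values shown sits.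

As far as these compounds go, what a longer unbranched chain such as hexyl, or an amine on the chain, would do in this assay stays open. Also open, from the compounds shown here alone, is whether larger branched saturated groups would go below the level shared by compounds 2 and 4.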